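The source may report more compounds than this note shows. Statements on the series, on what has been measured and on what is new or still open speak of the compounds shown alone.

Of the compounds shown here, three have been tested in a functional assay on cells (Leukemia cell, Homo sapiens) for cytotoxicity, read by sulforhodamine B assay, with a stated time of 48 h; a lower number here means a stronger inhibitor of growth, a higher number a weaker inhibitor of growth. Compound 1 `COc1ccc(C2CC(c3ccccc3)=NN2C2=NC(=O)/C(=C3\C(=O)Nc4ccc(Br)cc43)S2)cc1` gives 4230 nM. Compound 2 `COc1ccc(C2=NN(C3=NC(=O)/C(=C4\C(=O)Nc5ccc(Br)cc54)S3)C(c3ccc(OC)cc3)C2)cc1` gives 62700 nM. The two differ in one place: methoxy in place of hydrogen on an aromatic carbon. That single change produced a 15-fold higher number from compound 1 to compound 2 (1.17 log units; beyond the scatter). Compound 3 `O=C1N=C(N2N=C(c3ccccc3)CC2c2ccc(Cl)cc2)S/C1=C1/C(=O)Nc2ccccc21` gives 70800 nM, which is close to the value of compound 2 and much weaker than compound 1. The difference between the core of compound 3 and the core of compound 1 is not broken down here.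

Compound 4 `COc1ccc(C2=NN(C3=NC(=O)/C(=C4\C(=O)Nc5ccccc54)S3)C(c3ccc(Cl)cc3)C2)cc1` has not yet been measured in this assay. For the measured compounds named here, it is related to compound 3 by methoxy in place of hydrogen on an aromatic carbon, the same change as the one between compound 1 and compound 2, at a place described in the same words. If that change acts as it did before, the new compound should be a weaker growth inhibitor, though starting from an already high number the assay may run out of range. The earlier change gave a 15-fold higher number from compound 1 to compound 2 (1.17 log units; beyond the scatter), and this is the main support for the expectation. The expected step is a 2.5-fold higher number from compound 3 to compound 4 (0.41 log units; beyond the scatter). Compound 4 is estimated to give 180000 nM, within a range from 50000 nM to 500000 nM.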

Compound 4, concentration for total growth inhibition: 90900 nM
Compound 4: the middle estimate sits 2.0-fold (0.30 log units) above what was measured; measured number inside the range.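

In this assay the change from phenyl to 4-methoxyphenyl gave a 1.3-fold higher number from compound 3 to compound 4 (0.11 log units; within the scatter) and so made no clear difference on the core of compound 3. The large step seen earlier therefore did not carry over to this second core, and the two steps differ by more than chance scatter would explain: the same change on two cores in this assay, a 15-fold higher number (1.17 log units; beyond the scatter) from compound 1 to compound 2 and a 1.3-fold higher number (0.11 log units; within the scatter) from compound 3 to compound 4, 12-fold (1.06 log units) apart, beyond the scatter of two such steps

This shows that, within these four compounds, the size of the methoxy step was not the same on the two cores, so a step measured on one core was a poor guide to the step on the other. For the compounds shown here, with only two pairs, it does not show which structural difference between the cores matters, and it gives no rule for any further core.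

The compounds shown leave open what another group at this place, para to a large group, such as a hydroxyl, an amine or a carboxylic acid, would do on either core. They also leave open whether the methoxy step on a third core would resemble the large step or the small one.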